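A few compounds are considered here, and "the series" means these few. Any claim that something is new, unique, unknown or untested is made for them only; others in the source may bear on it.

Three compounds share one core and differ only in the group carried on the six-membered aromatic ring of carbon only. Compound 1 `CCOC(=O)C1=C(C)N/C(=C/c2cc(C)n(-c3ccc(Cl)cc3)c2C)C1=O` gives 1.6 ug/mL in a physicochemical assay for solubility, read by nephelometry, in phosphate buffer, measured as kinetic solubility, at pH 6.5; a lower number here means a less soluble compound, a higher number a more soluble compound. Compound 2 `CCOC(=O)C1=C(C)N/C(=C/c2cc(C)n(-c3ccc(Br)cc3)c2C)C1=O` gives 2.1 ug/mL in this assay, and compound 3 `CCOC(=O)C1=C(C)N/C(=C/c2cc(C)n(-c3ccc(SC(F)(F)F)cc3)c2C)C1=O` gives 1 ug/mL in this assay. Compound 3 has the lowest of the three numbers: the step of a 1.6-fold lower number from compound 1 to compound 3 (0.20 log units; within the scatter) stays within the scatter, the step of a 2.1-fold lower number from compound 2 to compound 3 (0.32 log units; beyond the scatter) is a modest one beyond it, and the step of a 1.3-fold higher number from compound 1 to compound 2 (0.12 log units; within the scatter) is within the scatter as well. Compound 4 `CCOC(=O)C1=C(C)N/C(=C/c2cc(C)n(-c3ccc(CN4CCCCC4)cc3)c2C)C1=O` carries a different kind of change: (piperidin-1-yl)methyl in place of (trifluoromethyl)sulfanyl on an aromatic carbon. Within the data shown here, none of the measured steps brings in a group of this kind; all three measured steps, between a chloro, a bromo and a (trifluoromethyl)sulfanyl group, were small. The measured steps give no direct guide, so the expectation for compound 4 rests on the change itself. For compound 4 the expected step is a 15-fold higher number from compound 3 to compound 4 (1.18 log units; beyond the scatter) in this assay. Compound 4 is estimated at 15 ug/mL in this assay, within a range from 3 ug/mL to 60 ug/mL.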

Compound 4, solubility: 12.5 ug/mL
Estimate against measurement, compound 4: 1.2-fold (0.08 log units) above, within the range that was stated.
By their numbers in this assay, from the lowest: compounds 3, 1 and 2 (each within the scatter of the next, the first and the last beyond it); then compound 4.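

At this position, on an aromatic carbon para to a large group, the earlier exchanges among chloro, bromo and (trifluoromethyl)sulfanyl gave only small steps, while (piperidin-1-yl)methyl gives a much larger one in this assay: a 13-fold higher number from compound 3 to compound 4 (1.10 log units; beyond the scatter). Among these compounds, the picture holds against the other two compounds, with a 6.0-fold higher number from compound 2 to compound 4 (0.77 log units; beyond the scatter) and a 7.8-fold higher number from compound 1 to compound 4 (0.89 log units; beyond the scatter), so compound 4 stands clearly above all three and the position can show a far wider spread than the earlier compounds revealed. No measurement here explains why the number rises with this group.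

The compounds shown do not separate the part played by the piperidine ring from that of its nitrogen or its methylene link. A morpholin-4-ylmethyl group, a dimethylaminomethyl group or a plain cyclohexylmethyl group at this place would pull those parts apart.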